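A few compounds are considered here, and "the series" means these few. Any claim that something is new, unique, unknown or untested is made for them only; others in the source may bear on it.

Measured compounds:
Compound 1 `Cc1ccc2c(c1)c(=O)c(C(=O)Nc1ccc(Oc3ncnc4[nH]cc(-c5ccccc5)c34)c(F)c1)c(C)n2C` — 100 nM
Compound 2 `CCn1c(C)c(C(=O)Nc2ccc(Oc3ncnc4[nH]cc(-c5ccccc5)c34)c(F)c2)c(=O)c2cc(C)ccc21` — 150 nM

In an assay on isolated protein for inhibition of tyrosine-protein kinase receptor UFO (Homo sapiens), read by FRET and Z'-LYTE, with a stated time of 1.5 h (on this read-out lower numbers stand for stronger inhibition and higher numbers for weaker inhibition), compound 1 gives 100 nM, the lowest of the two numbers shown, and compound 2 gives 150 nM. For the measured compounds named here, the one measured step, a 1.5-fold higher number from compound 1 to compound 2 (0.18 log units; within the scatter), lies within the scatter, so the two compounds cannot be told apart. Compound 3 `Cc1c(C(=O)Nc2ccc(Oc3ncnc4[nH]cc(-c5ccccc5)c34)c(F)c2)c(=O)c2cc(C3=CCCC3)ccc2n1C` has not yet been measured. It differs from compound 1 by cyclopent-1-en-1-yl in place of methyl on an aromatic carbon. Going by the values given here, the only measured step concerns a saturated chain carbon bound to an aromatic nitrogen, a different place, and was small; no measured step touches the aromatic carbon that carries the methyl in compound 1. The data therefore give no basis for expecting a change in this assay beyond the scatter in either direction. For compound 3 a value of 120 nM is expected, within a wide range from 30 nM to 500 nM. This estimate means an expected step of a 1.2-fold higher number from compound 1 to compound 3 (0.08 log units; within the scatter).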

Compound 3, half-maximal inhibitory concentration: 3320 nM
Beside the measured number, compound 3's estimate is 28-fold (1.44 log units) below it; the whole stated range lies below it.
By their numbers in this assay, from the lowest: compounds 1 and 2 (each within the scatter of the next); then compound 3.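

In this assay, for the compounds shown here, this aromatic carbon proves sensitive to the group it carries: cyclopent-1-en-1-yl in place of methyl gives a 33-fold higher number from compound 1 to compound 3 (1.52 log units; beyond the scatter) while the only earlier step, on a saturated chain carbon bound to an aromatic nitrogen, stayed within the scatter. The position therefore does not treat all carbon-only groups alike, even though neither group has a hydrogen-bond donor, a hydrogen-bond acceptor or a net charge. No available evidence explains the size of this step.

With only methyl and cyclopent-1-en-1-yl shown at this carbon, it remains open whether the change follows from the ring, its double bond or the larger number of carbons. Ethyl, saturated cyclopentyl or an amine such as morpholine at this carbon could help separate these possibilities.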